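Swapping Thiophene for Pyridine: Compound 3 to Compound 4

The source may hold more compounds than are shown below. What is called first, only, known or untested is meant among the compounds shown, and "the series" means these compounds.

Of the compounds shown here, three built on one shared core have been measured in an in vitro assay on BTI-TN-5B1-4 cells for inhibition of Amine oxidase [flavin-containing] A (Homo sapiens), read by Amplex Red, with a stated time of 15 min, tested at 100 uM; a lower number here means less inhibition, a higher number more inhibition at the concentration tested (going by the name of the read-out). Compound 1 `N#Cc1ccc(-c2csc(N/N=C\c3cccnc3)n2)cc1` gives 40%, compound 2 `Fc1ccc(-c2csc(N/N=C\c3ccco3)n2)cc1` gives 40%, and compound 3 `Fc1ccc(-c2csc(N/N=C\c3cccs3)n2)cc1` gives 40%. Compound 3 thus stands level with compounds 1 and 2 at the digits shown, and the single measured step, no change at the digits printed from compound 2 to compound 3 (within the scatter), which puts thiophen-2-yl in place of furan-2-yl on a carbon with a double bond to nitrogen, stays within the scatter.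

Compound 4 `Fc1ccc(-c2csc(N/N=C\c3cccnc3)n2)cc1` has not yet been measured. It differs from compound 3 in one place: pyridin-3-yl in place of thiophen-2-yl on a carbon with a double bond to nitrogen. Two observations bear on this change. Exchanging one five-membered aromatic ring for another, as in no change at the digits printed from compound 2 to compound 3 (within the scatter), left the read-out unchanged. Compound 1, which carries pyridin-3-yl on a carbon with a double bond to nitrogen, gives 40%, the same figure as compound 3. Nothing here points to a shift beyond the scatter in this assay. Compound 4 is therefore expected to give 40%, within 28% to 52%. The expected step of no change at the digits printed from compound 3 to compound 4 (within the scatter) is estimated as none beyond the scatter.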

Compound 4, a percentage reported as inhibition, at one concentration (the size of the read-out at that concentration, not a potency): 40%
Beside the measured number, compound 4's estimate shows no gap at the digits printed, within the range that was stated.
By their numbers in this assay, from the lowest: compounds 1, 2, 3 and 4 (each within the scatter of the next).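

On a carbon with a double bond to nitrogen, a six-membered aromatic ring now stands in for a five-membered one: in this assay, pyridin-3-yl in place of thiophen-2-yl gives no change at the digits printed from compound 3 to compound 4 (within the scatter), and pyridin-3-yl in place of furan-2-yl gives no change at the digits printed from compound 2 to compound 4 (within the scatter). A second place also gets its first one-place comparison, since fluoro in place of cyano on an aromatic carbon gives no change at the digits printed from compound 1 to compound 4 (within the scatter). No measured evidence is available to explain these results.

All of the groups on that carbon are aromatic rings, so the compounds shown leave open how an amine, a carboxylic acid or a longer chain would read there. Each compound also has a reading at only one concentration, which leaves any difference in potency among them open.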